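Notes on a conjugate pair and one untested analogue

This account rests on a few compounds, and the source may have more. Where it says the series, first, only, none or still open, it means among the compounds named here.

Two compounds have numbers in a functional assay on HCT-116 cells (Homo sapiens) for cytotoxicity, read by sulforhodamine B assay, with a stated time of 48 h, in the presence of a further agent that is not named here; on this read-out lower numbers stand for stronger inhibition and higher numbers for weaker inhibition. Compound 1 `O=C(CCCCCN1C(=O)CC(SCCOCCOCCOc2cc(O)c(C(=O)CCc3ccc(O)cc3)c(O)c2)C1=O)OCn1cc(F)c(=O)[nH]c1=O` gives 82800 nM. Among the compounds with values here, compound 2 `O=C(CCCSSCCOCCOCCOc1cc(O)c(C(=O)CCc2ccc(O)cc2)c(O[C@@H]2O[C@H](CO)[C@@H](O)[C@H](O)[C@H]2O)c1)OCn1cc(F)c(=O)[nH]c1=O` gives 23800 nM, the lowest of the two numbers; its only neighbour, compound 1, sits higher by a margin beyond the scatter. Within the data shown here, these two compounds differ in more than one place, so no single step is counted between them; their values show only that compound 2 sits at the stronger end. Compound 3 `O=C(CCCSSCCOCCOCCOc1cc(O)c(C(=O)CCc2ccc(O)cc2)c(O)c1)OCn1cc(F)c(=O)[nH]c1=O` has not yet been measured. It differs from compound 2 in one place: hydrogen in place of 3,4,5-trihydroxy-6-(hydroxymethyl)oxan-2-yl on an oxygen on an aromatic ring. Among the measured compounds shown here, no measured pair shows the effect of this change alone. A modest rise in the number is expected for compound 3, a 1.9-fold higher number from compound 2 to compound 3 (0.28 log units; within the scatter), near the edge of the scatter. Compound 3 is estimated at 45000 nM, within 15000 nM to 130000 nM.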

Compound 3, half-maximal inhibitory concentration: 10500 nM
For compound 3 the middle estimate is 4.3-fold (0.63 log units) above the measured one, and the stated range ends above it.
By their numbers in this assay, from the lowest: compound 3; then compound 2; then compound 1.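

Hydrogen in place of 3,4,5-trihydroxy-6-(hydroxymethyl)oxan-2-yl on an oxygen on an aromatic ring gives a 2.3-fold lower number from compound 2 to compound 3 (0.36 log units; beyond the scatter) in this assay, the first effect in this series that can be assigned to a single change. In this pair, the free hydroxy form reads as the stronger, so the 3,4,5-trihydroxy-6-(hydroxymethyl)oxan-2-yl group is not required for the activity seen here. Nothing available explains this step.

On these data alone, whether a smaller group on this oxygen, such as a methyl ether or an acetyl ester, would read closer to compound 3 or to compound 2 remains open. Also open, as far as these compounds go, is how the same change behaves on a different linker, for example a longer chain of plain methylene units.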